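Chain amide in place of a triazole on compound 1

The source may report more compounds than this note shows. Statements on the series, on what has been measured and on what is new or still open speak of the compounds shown alone.

Measured compounds:
compound 1, `Cn1ncc(Cl)c1-c1cc(C(=O)N[C@@H]2CN[C@H](CCn3cncn3)C[C@H]2c2ccc(Cl)c(Cl)c2)oc1Cl`, 4.47 nM
compound 2, `Cn1ncc(Cl)c1-c1cc(C(=O)N[C@@H]2CN[C@H](CCO)C[C@H]2c2ccc(F)c(F)c2)oc1Cl`, 0.98 nM
compound 3, `CC(=O)NCC[C@@H]1C[C@@H](c2ccc(F)c(F)c2)[C@H](NC(=O)c2cc(-c3c(Cl)cnn3C)c(Cl)o2)CN1`, 2.49 nM

In an assay for inhibition of RAC-alpha serine/threonine-protein kinase (Homo sapiens), read by HTRF, with a stated time of 1 h (on this read-out higher numbers stand for weaker inhibition and lower numbers for stronger inhibition), compound 1 gives the highest of the three numbers. Its nearest neighbour is compound 3, whose value of 2.49 nM lies within the scatter of it; compound 2, with 0.98 nM, stands furthest off, beyond the scatter.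

Compound 4, `Cn1ncc(Cl)c1-c1cc(C(=O)N[C@@H]2CN[C@H](CC(=O)NC3CCC3)C[C@H]2c2ccc(Cl)c(Cl)c2)oc1Cl`, is not yet measured. It differs from compound 1 in one place: cyclobutylcarbamoyl in place of (1H-1,2,4-triazol-1-yl)methyl on a saturated chain carbon bound to a saturated ring carbon.

For the measured compounds named here, only one measured step touches a related change, the exchange of a chain end group on the difluorophenyl pair: a 2.5-fold higher number from compound 2 to compound 3 (0.40 log units; beyond the scatter). That step swapped a hydroxy for an acetamido; here a triazole ring leaves and a cyclobutylcarbamoyl enters, so the bearing is loose. On this basis a modest step toward weaker inhibition, or none beyond the scatter, is expected in this assay for compound 4, about a 1.5-fold higher number from compound 1 to compound 4 (0.16 log units; within the scatter). Compound 4 is therefore estimated at 6.5 nM, with a range from 2 nM to 20 nM.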

Compound 4, half-maximal inhibitory concentration: 7.98 nM
For compound 4 the middle estimate is 1.2-fold (0.09 log units) below the measured one; the measured number falls inside the stated range.
By their numbers in this assay, from the lowest: compound 2; then compounds 3, 1 and 4 (each within the scatter of the next, the first and the last beyond it).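

In this assay the exchange on a saturated chain carbon bound to a saturated ring carbon gives a 1.8-fold higher number from compound 1 to compound 4 (0.25 log units; within the scatter) and thus shows that, with the core of compound 1, this place accepts a cyclobutylcarbamoyl group in place of the triazole-bearing end without a change beyond the scatter. For the compounds shown here, the earlier step at this chain end, a 2.5-fold higher number from compound 2 to compound 3 (0.40 log units; beyond the scatter), was seen only on the difluorophenyl pair, and the new step adds a reading on the dichlorophenyl pair, where a five-membered aromatic ring gives way to a four-membered ring of carbon only. Nothing shown bears on the reason for this result.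

The compounds shown leave open how a hydroxy or acetamido end would read on the dichlorophenyl pair. They also leave open whether a carboxylic acid, a primary amine or a longer chain at this place would stay within the scatter of compound 1.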